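A few compounds are considered here, and "the series" means these few. Any claim that something is new, unique, unknown or untested is made for them only; others in the source may bear on it.

Series notes. Compound 1 `Cc1cc(C)cc(Cc2ccc3c(NCCCNCc4ccco4)ccnc3c2)c1`, compound 2 `COc1cccc(CNCCCNc2ccnc3cc(Cc4cc(C)cc(C)c4)ccc23)c1O` and compound 3 `COc1ccc(F)cc1CNCCCNc1ccnc2cc(Cc3cc(C)cc(C)c3)ccc12` share one core and differ only in the group carried on the saturated chain carbon bound to the amine nitrogen. In an ADME assay for permeability, using PAMPA, with a stated time of 30 min, at pH 7.4 (a higher number here means that the compound crosses the layer faster, a lower number that the compound crosses the layer more slowly), compound 1 gives 23 10^-6 cm/s, compound 2 gives 23 10^-6 cm/s and compound 3 gives 23 10^-6 cm/s. Compound 2 thus stands level with compounds 1 and 3 at the digits shown; the steps of no change at the digits printed from compound 1 to compound 2 (within the scatter), no change at the digits printed from compound 1 to compound 3 (within the scatter) and no change at the digits printed from compound 2 to compound 3 (within the scatter) all lie within the scatter. Compound 4 `COc1ccccc1Oc1ccc2c(NCCCNCc3cccc(OC)c3O)ccnc2c1`, not yet measured, differs from compound 2 at a different place in the molecule: 2-methoxyphenoxy in place of 3,5-dimethylbenzyl on an aromatic carbon. Going by the values given here, none of the measured steps touches that aromatic carbon; all three concern the group on the chain carbon bound to the amine nitrogen, so they give no direct reading on the change from compound 2 to compound 4. Among the compounds with values here, they show only that swapping groups at the chain end leaves this assay unmoved. On that basis no step beyond the scatter is forecast in either direction, but the lack of a matching precedent widens the range. The expected step from compound 2 to compound 4 in this assay is a 1.2-fold lower number from compound 2 to compound 4 (0.06 log units; within the scatter). Compound 4 is estimated at 20 10^-6 cm/s, between 8 10^-6 cm/s and 40 10^-6 cm/s.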

Compound 4, apparent permeability: 317 10^-6 cm/s
Beside the measured number, compound 4's estimate is 16-fold (1.20 log units) below it, and the stated range ends below it.
By their numbers in this assay, from the lowest: compounds 1, 2 and 3 (each within the scatter of the next); then compound 4.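

In this assay, 2-methoxyphenoxy in place of 3,5-dimethylbenzyl on the aromatic carbon gives a 14-fold higher number from compound 2 to compound 4 (1.14 log units; beyond the scatter), so this position of the shared core can move the read-out strongly, while the three swaps at the chain carbon bound to the amine nitrogen all stayed within the scatter. The two groups match in heavy-atom count and each holds one six-membered aromatic ring of carbon only; they differ in that the entering group brings oxygen atoms and hydrogen-bond acceptors, and the chain end of compound 2 stays unchanged in compound 4. No measurement in hand says what lies behind the size of this step.

Going by these compounds alone, the single change combines an oxygen link with a methoxy group on the ring, so the part each plays stays open; plain phenoxy and 2-methoxybenzyl at this aromatic carbon would separate them. Going by these compounds, it also stays open whether the step carries over to compounds with furan-2-yl or 5-fluoro-2-methoxyphenyl at the chain end, and whether an amine or a carboxylic acid on the ring of the entering group would keep it.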